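Lengthening the Acid Chain of Compound 1

The compounds below may be only part of what the source reports. "The series", "measured", "known", "first", "only" and "open" are said of these compounds alone.

Measured compounds:
compound 1 `O=C(O)COc1cccc(CCCn2cc(C(c3ccccc3)c3ccccc3)ccc2=O)c1`: 42 nM
compound 2 `O=C(O)COc1cccc(CCCN(CCC(c2ccccc2)c2ccccc2)C(=O)c2ccccc2)c1`: 9.7 nM

Among the compounds with values here, in an assay on HEK293 cells for displacement of a labelled ligand from prostaglandin D2 receptor 2 (Homo sapiens), read by scintillation counting, with a stated time of 2 h (on this read-out lower numbers stand for stronger inhibition and higher numbers for weaker inhibition), compound 1 gives 42 nM, the higher of the two numbers measured so far. Compound 2 gives 9.7 nM in this assay, and its number is lower than that of compound 1 by more than the usual scatter. Within the data shown here, the two measured compounds differ in several places at once, so no single step between them can be read off.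

Compound 3 `O=C(O)CCCOc1cccc(CCCn2cc(C(c3ccccc3)c3ccccc3)ccc2=O)c1` differs from compound 1 in one place only: 2-carboxyethyl in place of carboxy on a saturated chain carbon bound to an oxygen on an aromatic ring. Seen one bond further out, the acid-bearing chain grows from carboxymethoxy to 3-carboxypropoxy. Among the measured compounds shown here, nothing among the measured compounds shows what such a change does, so the expectation rests on compound 1 alone. Compound 3 is expected to give a higher number than compound 1, a step of a 2.9-fold higher number from compound 1 to compound 3 (0.46 log units; beyond the scatter) that is expected to lie beyond the scatter. The estimate for compound 3 is 120 nM, with a range from 35 nM to 450 nM.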

Compound 3, half-maximal inhibitory concentration: 11 nM
Compound 3: middle estimate off by 11-fold (1.04 log units), on the high side; the whole stated range lies above it.
By their numbers in this assay, from the lowest: compounds 2 and 3 (each within the scatter of the next); then compound 1.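

Lengthening the acid chain from carboxymethoxy to 3-carboxypropoxy in this assay gives a 3.8-fold lower number from compound 1 to compound 3 (0.58 log units; beyond the scatter) and thus moves the number down, a modest step beyond the scatter. Within the data shown here, this is the first reading at this position, on a saturated chain carbon bound to an oxygen on an aromatic ring, and it shows that, on the core of compound 1, the carboxylic acid need not stay on the shorter chain. No measurement at hand bears on why the longer chain gives the lower number.

On these data alone, with only these two chain lengths in view, it remains open whether 2-carboxyethoxy would fall between them or whether 4-carboxybutoxy would lower the number further. The compounds shown also leave open whether the same lengthening would act alike on the acid chain of compound 2.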